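Fluorinated aryloxy variants of a peptidyl ketone series

The compounds below may be only part of what the source reports. "The series", "measured", "known", "first", "only" and "open" are said of these compounds alone.

Measured compounds:
- compound 1, `CC(C)[C@H](NC(=O)COc1cccc2ccccc12)C(=O)N[C@@H](CC(=O)O)C(=O)COc1ccc(C#N)cc1`: 26700 nM
- compound 2, `CC(C)[C@H](NC(=O)COc1cccc2ccccc12)C(=O)N[C@@H](CC(=O)O)C(=O)COc1ccc(F)cc1`: 14300 nM
- compound 3, `CC(C)[C@H](NC(=O)COc1cccc2ccccc12)C(=O)N[C@@H](CC(=O)O)C(=O)COc1cc(F)cc(F)c1F`: 11200 nM

All three share one core and differ only in the aryl group on the oxygen on the saturated carbon next to the ketone. In a functional assay with Homo sapiens as the target (a higher number here means a weaker inhibitor, a lower number a stronger inhibitor), compound 1 gives the highest number of the three. Its nearest neighbour is compound 2, reached by a 1.9-fold lower number from compound 1 to compound 2 (0.27 log units; within the scatter); the furthest is compound 3, reached by a 2.4-fold lower number from compound 1 to compound 3 (0.38 log units; beyond the scatter). Between the two fluorinated analogues the gap is a 1.3-fold lower number from compound 2 to compound 3 (0.11 log units; within the scatter).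

Compound 4, `CC(C)[C@H](NC(=O)COc1cccc2ccccc12)C(=O)N[C@@H](CC(=O)O)C(=O)COc1c(F)c(F)c(F)c(F)c1F`, has not yet been measured. Its difference from compound 1 is 2,3,4,5,6-pentafluorophenyl in place of 4-cyanophenyl on an oxygen on a saturated carbon. Among the measured compounds shown here, the steps that bear on this are the two replacements of the 4-cyanophenyl group already seen: the single fluoro for cyano gave a 1.9-fold lower number from compound 1 to compound 2 (0.27 log units; within the scatter), and the 2,3,5-trifluorophenyl gave a 2.4-fold lower number from compound 1 to compound 3 (0.38 log units; beyond the scatter). Both point in the same direction, one of them beyond the scatter, and adding further fluorines from compound 2 to compound 3 changed little. A step of similar size, towards a lower number, is therefore expected in this assay, roughly a 2.7-fold lower number from compound 1 to compound 4 (0.43 log units; beyond the scatter). Compound 4 is estimated at 10000 nM, with a range of 4000 nM to 25000 nM.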

Compound 4, half-maximal inhibitory concentration: 8890 nM
For compound 4 the middle estimate is 1.1-fold (0.05 log units) above the measured one; measured number inside the range.
By their numbers in this assay, from the lowest: compounds 4, 3, 2 and 1 (each within the scatter of the next, the first and the last beyond it).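

Replacing 4-cyanophenyl with 2,3,4,5,6-pentafluorophenyl gives a 3.0-fold lower number from compound 1 to compound 4 (0.48 log units; beyond the scatter) in this assay and so adds a second aryl group at this position whose step from compound 1 lies beyond the scatter. Within the fluorinated set, a 1.6-fold lower number from compound 2 to compound 4 (0.21 log units; within the scatter) and a 1.3-fold lower number from compound 3 to compound 4 (0.10 log units; within the scatter) show that going to the pentafluorophenyl group moves the number by no more than the scatter from either less fluorinated analogue, so the count of fluorines does not separate these compounds in this assay. No measurement is available to explain these steps.

The aryl groups shown carry only fluoro or nitrile substituents, so an unsubstituted phenyl, a methoxy-substituted phenyl, a carboxylic acid on the ring or a saturated chain in place of the ring remains open. Also open, as far as these compounds go, is whether these small steps would persist with other parts of the shared core changed.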